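A few compounds are considered here, and "the series" means these few. Any claim that something is new, unique, unknown or untested is made for them only; others in the source may bear on it.

Measured so far:
- compound 1 `COc1cc(CNC(=O)/C=C/c2cccc(OC)c2OC)ccc1OCc1nc(C)c(C)nc1C` — 7150 nM in a functional assay on SH-SY5Y cells (Homo sapiens) for cytotoxicity, read by MTT assay, with stated times of 24 h and 4 h; on this read-out lower numbers stand for an effect already at smaller amounts and higher numbers for an effect only at larger amounts of compound
- compound 2 `COc1cc(/C=C/C(=O)NCc2ccc(O)c(OC)c2)cc(OC)c1` — 4860 nM in this assay

Both numbers come from the same read-out, and the gap between them is within the usual scatter of repeated measurements, so neither compound stands apart from the other. Compound 2 holds the lower of the two numbers, but only nominally; compound 1, with its trimethylpyrazinylmethyl ether on the amide-side ring and a different arrangement of methoxy groups on the cinnamoyl ring, sits close to it.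

Compound 3 `COc1cc(/C=C/C(=O)NCc2ccc(OCc3nc(C)c(C)nc3C)c(OC)c2)cc(OC)c1` is the pending member. It differs from compound 2 in one place: (3,5,6-trimethylpyrazin-2-yl)methyl in place of hydrogen on an oxygen on an aromatic ring. Compound 3 thus carries the same ether seen in compound 1 together with the cinnamoyl substitution of compound 2. For the measured compounds named here, no directly comparable pair has been measured, so the expected step rests only on the closeness of compound 1 and compound 2 in this assay. The step is expected to be small, with no direction that would rise beyond the scatter: a 1.2-fold higher number from compound 2 to compound 3 (0.09 log units; within the scatter). Compound 3 is therefore estimated at 6000 nM, within a range of 2800 nM to 13000 nM.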

Compound 3, half-maximal effective concentration: 8660 nM
The estimate for compound 3 lay 1.4-fold (0.16 log units) below the measured number, and the stated range covers the measured number.
By their numbers in this assay, from the lowest: compounds 2, 1 and 3 (each within the scatter of the next).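

In this assay, for the compounds shown here, (3,5,6-trimethylpyrazin-2-yl)methyl in place of hydrogen on an oxygen on an aromatic ring gives a 1.8-fold higher number from compound 2 to compound 3 (0.25 log units; within the scatter) and so provides the first one-place comparison at this oxygen: on these compounds, the change from hydroxy to (3,5,6-trimethylpyrazin-2-yl)methoxy is not separated from repeat-measurement variation. With that ether held constant, 3,5-dimethoxyphenyl in place of 2,3-dimethoxyphenyl on a double-bonded chain carbon bound to a double-bonded chain carbon gives a 1.2-fold higher number from compound 1 to compound 3 (0.08 log units; within the scatter) and shows that this assay does not separate these two dimethoxyphenyl groups either. No measurement accompanying these steps accounts for either result.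

As far as these compounds go, both readings rest on single pairs, so it remains open whether the same steps would hold on a different core or with a different group on the double-bonded chain. From the compounds shown here alone, it also remains open whether an aminoethyl or carboxymethyl group on this oxygen, or a longer alkyl chain there, would give a step beyond the scatter in this assay rather than one within it.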